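The source may hold more compounds than are shown below. What is called first, only, known or untested is meant among the compounds shown, and "the series" means these compounds.

Working notes on the series. Among the measured compounds shown here, compound 3, `C[C@@H]1CN(c2sc(C(F)(F)F)nc2-c2nc3ccccc3[nH]2)CCN1C(=O)Cn1cc(Cl)cn1`, carries a 4-chloro-1H-pyrazol-1-yl on a saturated chain carbon bound to a carbonyl carbon, and in a functional assay on Venous blood for antagonist activity at C-X-C chemokine receptor type 3 (Homo sapiens), read by flow cytometry, with a stated time of 30 min, in the presence of a further agent that is not named here (a lower number here means a stronger inhibitor, a higher number a weaker inhibitor), compound 3 gives 251 nM, the lowest of the three numbers so far. Compound 1, `Cc1nn(CC(=O)N2CCN(c3sc(C(F)(F)F)nc3-c3nc4ccccc4[nH]3)C[C@H]2C)cc1CN(C)C`, gives 330 nM in this assay; the step of a 1.3-fold lower number from compound 1 to compound 3 (0.12 log units; within the scatter). Compound 2, `C[C@@H]1CN(c2sc(C(F)(F)F)nc2-c2nc3ccccc3[nH]2)CCN1C(=O)CN1CCC(F)(F)CC1`, gives 2430 nM in this assay; the step of a 9.7-fold lower number from compound 2 to compound 3 (0.99 log units; beyond the scatter), and likewise a 7.4-fold higher number from compound 1 to compound 2 (0.87 log units; beyond the scatter). Among the three, swapping one five-membered aromatic group for another left the number unchanged within the scatter, whereas the saturated 4,4-difluoropiperidin-1-yl stood apart.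

Compound 4, `C[C@@H]1CN(c2sc(C(F)(F)F)nc2-c2nc3ccccc3[nH]2)CCN1C(=O)Cn1cnc2cccnc21`, has not yet been measured. Relative to compound 3 the change is a group of 9 heavy atoms (6 carbon, 3 nitrogen; one five-membered aromatic ring with 2 hetero atoms, one six-membered aromatic ring with 1 hetero atom) in place of a group of 6 heavy atoms (3 carbon, 2 nitrogen, 1 chlorine; one five-membered aromatic ring with 2 hetero atoms), on a saturated chain carbon bound to a carbonyl carbon. For the measured compounds named here, the step from compound 1 to compound 3 is the closest precedent, an aromatic five-membered group exchanged for another at the same place and within the scatter; the step from compound 2 to compound 3 concerns a saturated group and bears less directly. Compound 4 keeps an aromatic five-membered ring with two hetero atoms and adds a fused six-membered aromatic ring; the expected step is a 1.3-fold higher number from compound 3 to compound 4 (0.11 log units; within the scatter), that is, no change beyond the scatter. Compound 4 is therefore estimated at 320 nM in this assay, with a range of 120 nM to 900 nM.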

Compound 4, half-maximal inhibitory concentration: 70 nM
Estimate against measurement, compound 4: 4.6-fold (0.66 log units) above, outside the stated range (below it).
By their numbers in this assay, from the lowest: compound 4; then compounds 3 and 1 (each within the scatter of the next); then compound 2.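

At this position, on a saturated chain carbon bound to a carbonyl carbon, exchanging one aromatic group for another is not always neutral, as compounds 1 and 3 alone might have suggested: in this assay there is a 3.6-fold lower number from compound 3 to compound 4 (0.55 log units; beyond the scatter) and a 4.7-fold lower number from compound 1 to compound 4 (0.67 log units; beyond the scatter), both steps leading to the group that adds a six-membered aromatic ring with 1 hetero atom. Compound 4 thus has the lowest number of the four, with its steps to all three others printed as beyond the scatter, and the group at this position can do more than match the two pyrazole-bearing compounds. Among the compounds shown here, the gap to the saturated ring also widens, with a 35-fold lower number from compound 2 to compound 4 (1.54 log units; beyond the scatter), the largest step so far. Nothing shown here offers a measured explanation for these differences.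

The compounds shown leave open whether the lower number depends on the hetero atom of the six-membered ring, which a benzimidazol-1-yl group, with carbon in its place, would test. They also leave open how a morpholin-4-yl group or a carboxylic acid at this position would read out.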